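Halogen swap on two related nucleoside cores

The compounds below may be only part of what the source reports. "The series", "measured", "known", "first", "only" and "open" are said of these compounds alone.

Measured so far:
compound 1, `C#C[C@@]1(O)[C@@H](CO)O[C@@H](n2cc(Cl)c3c(N)ncnc32)[C@@H]1O`: 12 nM
compound 2, `C#C[C@@]1(O)[C@@H](CO)O[C@@H](n2cc(I)c3c(N)ncnc32)[C@@H]1O`: 120 nM
compound 3, `C#C[C@@]1(O)[C@@H](CO)O[C@@H](n2cc(Cl)c3c(N)ccnc32)[C@@H]1O`: 5400 nM

In a functional assay on CCRF-CEM cells (Homo sapiens) for antiproliferative activity, read by cell counting, with a stated time of 72 h (on this read-out higher numbers stand for weaker inhibition and lower numbers for stronger inhibition), compound 1 gives 12 nM. Compound 2 carries iodo in place of chloro on an aromatic carbon and in this assay gives 120 nM, a change of a 10-fold higher number from compound 1 to compound 2 (1.00 log units; beyond the scatter). Compound 3 has a different core; the difference between the two cores is not broken down here, and in this assay compound 3 gives 5400 nM. Compound 4, `C#C[C@@]1(O)[C@@H](CO)O[C@@H](n2cc(I)c3c(N)ccnc32)[C@@H]1O`, is not yet measured; it differs from compound 3 by iodo in place of chloro on an aromatic carbon, the same change as from compound 1 to compound 2, at a place described in the same words. The step from compound 3 to compound 4 is therefore expected to be an 8.3-fold higher number from compound 3 to compound 4 (0.92 log units; beyond the scatter), resting on the measured step of a 10-fold higher number from compound 1 to compound 2 (1.00 log units; beyond the scatter). The estimated value of compound 4 in this assay is 45000 nM, within 12000 nM to 160000 nM.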

Compound 4, half-maximal inhibitory concentration: 310 nM
Compound 4: middle estimate off by 150-fold (2.16 log units), on the high side, outside the stated range (below it).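

In this assay, iodo in place of chloro gives a 17-fold lower number from compound 3 to compound 4 (1.24 log units; beyond the scatter), so the change does not run the same way on this core as on the core of compound 1. The two steps point in opposite directions, and the gap between them is larger than repeated measurements would explain: the same change on two cores in this assay, a 10-fold higher number (1.00 log units; beyond the scatter) from compound 1 to compound 2 and a 17-fold lower number (1.24 log units; beyond the scatter) from compound 3 to compound 4, 170-fold (2.24 log units) apart, beyond the scatter of two such steps. This shows that, for these compounds, the effect of the swap depends on the core carrying it, but it does not show which difference between the cores matters, and two pairs give no rule for a further core.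

Only chloro and iodo appear at this place in the compounds shown, so it remains open how bromo or a methyl group would behave there on either core.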